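Hydroxyphenyl series notes: from compound 3 to compound 4

The source may report more compounds than this note shows. Statements on the series, on what has been measured and on what is new or still open speak of the compounds shown alone.

Values in an assay on isolated protein for inhibition of DNA topoisomerase 1 (Homo sapiens), with a stated time of 30 min, tested at 100 uM; a higher number here means a stronger effect of the compound at the concentration tested, a lower number a weaker effect:
compound 1 `Oc1ccc(-c2cc(-c3cccs3)cc(-c3ccc(O)cc3)n2)cc1` gives 86.3%
compound 2 `Oc1ccc(-c2cc(-c3ccsc3)cc(-c3ccc(O)cc3)n2)cc1` gives 61.7%
compound 3 `Oc1ccc(-c2cc(-c3ccco3)cc(-c3ccccc3O)n2)cc1` gives 83%

Compound 3 stands second highest of the three; its difference to compound 1 lies within the scatter, while compound 2 lies beyond the scatter below it. Compound 4 `Oc1ccc(-c2cc(-c3ccco3)cc(-c3ccc(O)cc3)n2)cc1` is not yet measured and differs from compound 3 by 4-hydroxyphenyl in place of 2-hydroxyphenyl on an aromatic carbon. For the measured compounds named here, the only measured step, a number 24.6 percentage points lower from compound 1 to compound 2 (beyond the scatter), concerns the thiophenyl group and does not bear on a hydroxyphenyl change. Compound 1, which already carries the 4-hydroxyphenyl group that enters here, gives 86.3%, within the scatter of compound 3. No step beyond the scatter is therefore expected; the expected step is a number 1 percentage points lower from compound 3 to compound 4 (within the scatter). Compound 4 is estimated at 82%, ranging from 62% to 95%.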

Compound 4, a percentage reported as inhibition, at one concentration (the size of the read-out at that concentration, not a potency): 100%
Compound 4: the middle estimate sits 18 percentage points below what was measured, and the stated range ends below it.
By their numbers in this assay, from the lowest: compound 2; then compounds 3 and 1 (each within the scatter of the next); then compound 4.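

Position next to the ring nitrogen: with furan-2-yl unchanged, the place of the hydroxyl on the phenyl group counts in this assay, as 4-hydroxyphenyl in place of 2-hydroxyphenyl gives a step beyond the scatter (a number 17 percentage points higher from compound 3 to compound 4 (beyond the scatter)). With two 4-hydroxyphenyl groups held constant, the five-membered ring also counts: furan-2-yl exceeds thiophen-3-yl (a number 38.3 percentage points higher from compound 2 to compound 4 (beyond the scatter)) and thiophen-2-yl (a number 13.7 percentage points higher from compound 1 to compound 4 (beyond the scatter)). No measurement here accounts for these steps. Open, from the compounds shown here alone, is whether the 2-hydroxyphenyl to 4-hydroxyphenyl step holds with thiophen-2-yl in place of furan-2-yl. Also open, going by these compounds, is how an amine or a carboxylic acid in place of the hydroxyl would read.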